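Cyclopentyl for butyl on sulfur: cytotoxicity notes

The source may report more compounds than this note shows. Statements on the series, on what has been measured and on what is new or still open speak of the compounds shown alone.

Measured so far in an ADME assay on MT4 cells (Homo sapiens) for activation, read by MTT assay; on this read-out higher numbers stand for lower toxicity in this test and lower numbers for higher toxicity in this test:
Compound 1, `CCCCSc1nc(Cc2c(F)cccc2Cl)cc(=O)[nH]1`, gives only an assay limit, > 76000 nM.
Compound 2, `O=c1cc(Cc2c(F)cccc2Cl)nc(SC2CCCC2)[nH]1`, gives only an assay limit, > 74000 nM.
Compound 3, `CCCCSc1nc(C(CC)c2c(F)cccc2F)c(C)c(=O)[nH]1`, gives only an assay limit, > 3000 nM.

Every value in this assay is a limit and not a number, as the limit of > 76000 nM in this assay, at which 1 of the 3 values shown sits, the limit of > 74000 nM in this assay, at which 1 of the 3 values shown sits, and the limit of > 3000 nM in this assay, at which 1 of the 3 values shown sits, show. The change cyclopentyl in place of butyl on a sulfur gives a step that the two limits leave unreadable from compound 1 to compound 2; with both ends at a limit, its size cannot be read. Compound 4, `CCC(c1nc(SC2CCCC2)[nH]c(=O)c1C)c1c(F)cccc1F`, is not yet measured and arises from compound 3 by the same change, (cyclopentyl in place of butyl on a sulfur), at the same place. The difference between the core of compound 1 and the core of compound 3 is not broken down here.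

For the measured compounds named here, the only measured precedent for this change is unreadable, so no direction can be taken from it. Compound 4 is therefore expected to give 40000 nM, most probably reported again as a limit, because the limit of > 3000 nM in this assay, at which 1 of the 3 values shown sits, already places compound 3 at one. The step from compound 3 to compound 4 is estimated as a step that the limit leaves unreadable from compound 3 to compound 4, expected to stay within the usual scatter.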

Compound 4, half-maximal cytotoxic concentration: 30000 nM
Compound 4: the middle estimate sits 1.3-fold (0.12 log units) above what was measured, and the stated range covers the measured number.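

In this assay, for the compounds shown here, compound 3 gives only an assay limit, > 3000 nM, so no step to compound 4 can be read. The compounds shown leave open how large the effect of cyclopentyl in place of butyl on a sulfur is in this read-out, on the core of compound 1 and on the core of compound 3 alike.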